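The source may hold more compounds than are shown below. What is called first, only, known or untested is meant among the compounds shown, and "the series" means these compounds.

Compound 1 `COc1cc2c(Nc3ccc(C#N)cc3)ncnc2cc1OCCCN1CCCC1`: in a functional assay on MCF7 cells (Homo sapiens) for antiproliferative activity, read by MTT assay, with a stated time of 72 h (on this read-out lower numbers stand for stronger inhibition and higher numbers for weaker inhibition), compound 1 gives 16200 nM.
Compound 2 `COc1cc2c(Nc3ccc(C#N)cc3)ncnc2cc1OCCCN1CCCCC1CCO`: in this assay compound 2 reaches only the assay limit > 100000 nM, which is not a number.

Compound 2 therefore stands at the limit (the limit of > 100000 nM in this assay, at which 1 of the 2 values shown sits), with no number of its own. Going by the values given here, the one measured step, an at least 6.1-fold higher number from compound 1 to compound 2 (0.79 log units; beyond the scatter), lies beyond the scatter. Compound 3 `CCOC(=O)C1CCN(CCCOc2cc3ncnc(Nc4ccc(C#N)cc4)c3cc2OC)CC1` differs from compound 2 by 4-(ethoxycarbonyl)piperidin-1-yl in place of 2-(2-hydroxyethyl)piperidin-1-yl on a saturated chain carbon, three bonds along the chain from an oxygen on an aromatic ring. Among the compounds with values here, no measured step covers this exchange; the single step available concerns another change to the same ring and gives no direction for the present one. With compound 2 known only as a limit, the estimate for compound 3 can rest on nothing more than the spread between the value of compound 1 and the limit of compound 2. Compound 3 is expected at 40000 nM, between 10000 nM and 150000 nM. The step this implies, an at least 2.5-fold lower number from compound 2 to compound 3 (0.39 log units; beyond the scatter), is an expectation only.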

Compound 3, half-maximal inhibitory concentration: 34900 nM
Beside the measured number, compound 3's estimate is 1.1-fold (0.06 log units) above it; low and high end bracket the measured number.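

In this assay, compound 3 shows that a six-membered ring at this place on the chain does not by itself bring the read-out to the limit: 4-(ethoxycarbonyl)piperidin-1-yl in place of 2-(2-hydroxyethyl)piperidin-1-yl gives an at least 2.8-fold lower number from compound 2 to compound 3 (0.45 log units; beyond the scatter). Compound 2 remains a limit of the assay and not a number: the limit of > 100000 nM in this assay, at which 1 of the 3 values shown sits. Measured against the pyrrolidin-1-yl group, the new group still gives a 2.2-fold higher number from compound 1 to compound 3 (0.33 log units; beyond the scatter), so compound 1 keeps the lowest number of the three.

The compounds shown leave open whether the ring or the ethoxycarbonyl group accounts for the difference, which a plain piperidin-1-yl group or a carboxylic acid in place of the ester could separate. Also open, from the compounds shown here alone, is how a morpholin-4-yl group or a longer chain would read in this assay.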